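The compounds below may be only part of what the source reports. "The series", "measured", "known", "first", "only" and "open" are said of these compounds alone.

Measured so far:
Compound 1: `Cc1ccc(-c2csc(N/N=C/c3ccc(-n4ccnc4)cc3)n2)cc1` — 36%
Compound 2: `Clc1ccc(-c2csc(N/N=C/c3ccc(-n4cncn4)cc3)n2)cc1` — 28.4%

Both compounds were tested in an ADME assay on THP-1 cells (Homo sapiens) for cytotoxicity, read by MTT assay, tested at 50 ug/mL; on this read-out higher numbers stand for more inhibition at the one concentration tested (going by the name of the read-out) and lower numbers for less inhibition. On these two numbers compound 2 has the lower reading, but the gap to compound 1 lies within the usual scatter of repeated measurements, so the two cannot really be told apart; both show only modest inhibition at the single concentration tested.

The next compound is compound 3, `Cc1ccc(-c2csc(N/N=C/c3ccc(-n4cncn4)cc3)n2)cc1`. It is compound 2 with a single change: methyl in place of chloro on an aromatic carbon. Nothing else in the molecule is touched. Among the compounds with values here, because no two measured compounds differ in this one place alone, there is no measured step to lean on. The expectation for this assay is a step from compound 2 to compound 3 of a number 3.6 percentage points higher from compound 2 to compound 3 (within the scatter), that is, no change beyond the scatter in either direction. Compound 3 is therefore expected to give about 32% in this assay, most likely somewhere between 18% and 46%.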

Compound 3, a percentage reported as inhibition, at one concentration (the size of the read-out at that concentration, not a potency): 13.6%
Compound 3: middle estimate off by 18.4 percentage points, on the high side, and the stated range ends above it.
By their numbers in this assay, from the lowest: compound 3; then compounds 2 and 1 (each within the scatter of the next).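

In this assay, within the data shown here, methyl in place of chloro on the aromatic carbon para to a large group gives a number 14.8 percentage points lower from compound 2 to compound 3 (beyond the scatter), which shows that this position responds to the exchange of a single heavy atom, a sensitivity that no earlier pair could reveal. The other end of the molecule responds as well: 1H-1,2,4-triazol-1-yl in place of 1H-imidazol-1-yl on an aromatic carbon gives a number 22.4 percentage points lower from compound 1 to compound 3 (beyond the scatter), so compound 3 now links both earlier compounds through a change in one place each, and both changes reach beyond the scatter. Nothing available explains why the reading falls with either change.

Still open, going by these compounds, is how other groups at the same place on the phenyl ring would read, such as a methoxy, an amine or a carboxylic acid, and whether methyl stands out among them. Also open, on these data alone, is whether the step between 1H-imidazol-1-yl and 1H-1,2,4-triazol-1-yl would keep its direction and size with a 4-chlorophenyl group in the molecule.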